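The source may hold more compounds than are shown below. What is called first, only, known or untested is meant among the compounds shown, and "the series" means these compounds.

Measured so far in a functional assay for inhibition, with Homo sapiens as the target; a lower number here means tighter binding, a higher number weaker binding:
- compound 1 `CC(C)(Oc1ccccc1)C1OCC(C/C=C\CCC(=O)O)C(c2cccnc2)O1`: 75.9 nM
- compound 2 `COc1ccc(OC(C)(C)C2OCC(C/C=C\CCC(=O)O)C(c3cccnc3)O2)cc1`: 302 nM
- compound 3 `CC(C)(C1OCC(C/C=C\CCC(=O)O)C(c2cccnc2)O1)S(=O)(=O)c1ccccc1`: 3160 nM

Compound 3 carries the highest number of the three, and its steps to both others lie beyond the scatter. The next compound is compound 4 `CC(C)(Cc1ccccc1)C1OCC(C/C=C\CCC(=O)O)C(c2cccnc2)O1`, with the change (benzyl in place of phenylsulfonyl on a saturated chain carbon bound to two saturated chain carbons and a saturated ring carbon). For the measured compounds named here, two measured steps bear on this change, as both bring in the phenylsulfonyl group that compound 4 loses. These are a 42-fold higher number from compound 1 to compound 3 (1.62 log units; beyond the scatter) and a 10-fold higher number from compound 2 to compound 3 (1.02 log units; beyond the scatter), and both are large. The modest 4.0-fold higher number from compound 1 to compound 2 (0.60 log units; beyond the scatter) concerns only an aromatic carbon and bears on this change less directly. Going by the values given here, no measured compound carries benzyl, so the size of the step remains uncertain. A large step towards a lower number is nevertheless expected in this assay, since every measured compound without phenylsulfonyl sits lower. The expected change is a 13-fold lower number from compound 3 to compound 4 (1.10 log units; beyond the scatter). For compound 4 the estimate is 250 nM, with an expected range of 60 nM to 1000 nM.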

Compound 4, dissociation constant: 513 nM
Compound 4: middle estimate off by 2.1-fold (0.31 log units), on the low side, and the stated range covers the measured number.
By their numbers in this assay, from the lowest: compound 1; then compounds 2 and 4 (each within the scatter of the next); then compound 3.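

At this saturated chain carbon, with one six-membered aromatic ring of carbon only kept in each group, the group carrying that ring sets the number in this assay: benzyl in place of phenylsulfonyl gives a 6.2-fold lower number from compound 3 to compound 4 (0.79 log units; beyond the scatter), yet benzyl in place of phenoxy gives a 6.8-fold higher number from compound 1 to compound 4 (0.83 log units; beyond the scatter), so removing phenylsulfonyl does not by itself return the number of compound 1. Benzyl and 4-methoxyphenoxy cannot be told apart here, with a 1.7-fold higher number from compound 2 to compound 4 (0.23 log units; within the scatter) as the step. No measurement on hand accounts for this order of groups.

Still open, as far as these compounds go, is whether methoxy on the aromatic ring of compound 4 would repeat a 4.0-fold higher number from compound 1 to compound 2 (0.60 log units; beyond the scatter) in the benzyl setting. Also open, from the compounds shown here alone, is how an amine or an amide at this same carbon would compare with phenoxy.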